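A few compounds are considered here, and "the series" means these few. Any claim that something is new, unique, unknown or untested is made for them only; others in the source may bear on it.

In an ADME assay (liver) for metabolic stability, with Liver microsome (Rattus norvegicus) as the target, using microsomes (a lower number here means slower removal, a higher number faster removal of the compound), three compounds have been measured. Compound 1 `O=C(O)c1csc(-n2cc(-c3ccccc3)c3ccccc32)n1` gives 2400 mL/min/kg, compound 2 `O=C(O)c1csc(-n2nc(-c3ccccc3)c3ccncc32)n1` gives 69 mL/min/kg, and compound 3 `O=C(O)c1csc(-n2nc(-c3ccccc3)c3ccc(F)cc32)n1` gives 337 mL/min/kg. Compound 3 thus stands second highest of the three, and its gaps to compound 2 and to compound 1 both lie beyond the scatter of repeat measurements. Compound 4 `Nc1ccc2c(-c3ccccc3)nn(-c3nc(C(=O)O)cs3)c2c1` has amino in place of fluoro on an aromatic carbon. Within the data shown here, no two measured compounds differ in one place alone, so the expectation rests on little. The expected step of a 1.3-fold lower number from compound 3 to compound 4 (0.13 log units; within the scatter) is a small fall in this assay, not beyond the scatter. The estimate for compound 4 is 250 mL/min/kg, with an expected range of 90 mL/min/kg to 700 mL/min/kg.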

Compound 4, clearance: 208 mL/min/kg
The estimate for compound 4 lay 1.2-fold (0.08 log units) above the measured number; the range from low to high includes it.
By their numbers in this assay, from the lowest: compound 2; then compounds 4 and 3 (each within the scatter of the next); then compound 1.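

Among these compounds, this is the first step in which only one place changes, and in this assay amino in place of fluoro on this aromatic carbon gives a 1.6-fold lower number from compound 3 to compound 4 (0.21 log units; within the scatter) and so leaves the two groups indistinguishable at this position. The hydrogen-bond donor and acceptor that enter with amino therefore bring no step beyond the scatter. Nothing at hand bears on why this is so. From the compounds shown here alone, whether a larger group, such as methoxy or an acetamide, would also stay within the scatter of fluoro here remains open. So does whether amino would behave the same way on another carbon of this ring.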